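Adding a Nitro Group to Compound 1

This account rests on a few compounds, and the source may have more. Where it says the series, first, only, none or still open, it means among the compounds named here.

The three measured compounds share one core and differ only in the ring carried on the amine nitrogen. In a functional assay on SK-OV-3 cells (Homo sapiens) for inhibition, read by CCK-8 assay, with a stated time of 70 h (on this read-out higher numbers stand for weaker inhibition and lower numbers for stronger inhibition), compound 1 `c1ccc(COc2ccc(OCCOCCNC3CCCC3)cc2)cc1` gives 24800 nM, compound 2 `c1ccc(COc2ccc(OCCOCCNC3CCC3)cc2)cc1` gives 25000 nM, and compound 3 `c1ccc(COc2ccc(OCCOCCNC3CC3)cc2)cc1` gives 47200 nM. Compound 1 has the lowest of the three numbers, but its steps to the others, a 1.0-fold higher number from compound 1 to compound 2 (0.00 log units; within the scatter) and a 1.9-fold higher number from compound 1 to compound 3 (0.28 log units; within the scatter), both fall within the scatter, so these measurements do not separate the three compounds. The step of a 1.9-fold higher number from compound 2 to compound 3 (0.28 log units; within the scatter) is likewise within the scatter.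

Compound 4 `O=[N+]([O-])c1ccc(COc2ccc(OCCOCCNC3CCCC3)cc2)cc1` departs from compound 1 at a different place: nitro in place of hydrogen on an aromatic carbon. Going by the values given here, no measured step touches this part of the structure; all three known steps concern the ring on the amine nitrogen, and none of them moved the number beyond the scatter. Among the compounds with values here, the measurements thus give no precedent for the nitro group and point in no particular direction. The author therefore expects a step of a 1.1-fold lower number from compound 1 to compound 4 (0.05 log units; within the scatter) that stays within the scatter, with no fixed sign. Compound 4 is estimated to give 22000 nM, with a range from 7000 nM to 70000 nM, the width reflecting the absence of any directly comparable step.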

Compound 4, half-maximal inhibitory concentration: 20300 nM
For compound 4 the middle estimate is 1.1-fold (0.03 log units) above the measured one; the range from low to high includes it.
By their numbers in this assay, from the lowest: compounds 4, 1, 2 and 3 (each within the scatter of the next, the first and the last beyond it).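

Going by these compounds alone, compound 4 gives the first reading on a change outside the ring on the amine nitrogen: a substitution on an aromatic carbon of a six-membered aromatic ring of carbon only, para to a large group. In this assay, nitro in place of hydrogen there gives a 1.2-fold lower number from compound 1 to compound 4 (0.09 log units; within the scatter), so these measurements do not separate the 4-nitrophenyl compound from its phenyl parent, and adding a group of 3 heavy atoms at this place leaves the read-out within the scatter of compound 1. Nothing available here speaks to a cause for this result.

With only one group shown at this place, the compounds leave open whether another one, such as an amine, a carboxylic acid or a longer chain, would move the number beyond the scatter. They also leave open whether the same change from phenyl to 4-nitrophenyl would behave in the same way on compound 2 or compound 3, which carry the smaller rings on the amine nitrogen.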